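Fluoro for Methyl on Two Cores in a Cytotoxicity Series

A few compounds are considered here, and "the series" means these few. Any claim that something is new, unique, unknown or untested is made for them only; others in the source may bear on it.

Compound 1 `C/C(=C\c1ccc(-c2ccc(C)cc2)o1)C(N)=O` and compound 2 `C/C(=C\c1ccc(-c2ccc(F)cc2)o1)C(N)=O` share one core and differ at a single ring carbon. In a functional assay on HO8910 cells (Homo sapiens) for cytotoxicity, read by CCK-8 assay, with a stated time of 24 h (on this read-out lower numbers stand for stronger inhibition and higher numbers for weaker inhibition), compound 1 gives 1660 nM, and in the same assay compound 2 gives 990 nM. The change between them is fluoro in place of methyl on an aromatic carbon, and it made a 1.7-fold lower number from compound 1 to compound 2 (0.22 log units; within the scatter). Compound 3 `C/C(=C\c1nc(-c2ccc(C)cc2)cs1)C(N)=O` rests on a different core; the difference between the two cores is not broken down here. In this assay compound 3 gives > 50000 nM, which is a limit of the assay and not a number, as marked by the limit of > 50000 nM in this assay, at which 1 of the 3 values shown sits. Compound 4 `C/C(=C\c1nc(-c2ccc(F)cc2)cs1)C(N)=O` has not yet been measured in this assay. It carries the same kind of change as compound 2, namely (fluoro in place of methyl on an aromatic carbon), and the two place descriptions read alike word for word. The step from compound 3 to compound 4 is expected to be a number no higher from compound 3 to compound 4 (the limit leaves the size open), because the earlier step of a 1.7-fold lower number from compound 1 to compound 2 (0.22 log units; within the scatter) stayed within the scatter and because compound 3 sits at the limit of > 50000 nM in this assay, at which 1 of the 3 values shown sits. Compound 4 is therefore expected to give about 50000 nM, most likely reported again only as a limit, with the estimate spanning 20000 nM to 100000 nM.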

Compound 4, half-maximal inhibitory concentration: 4450 nM
For compound 4 the middle estimate is 11-fold (1.05 log units) above the measured one; the measured number lies below the stated range.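

In this assay, fluoro in place of methyl on an aromatic carbon gave an at least 11-fold lower number from compound 3 to compound 4 (1.05 log units; beyond the scatter). The size of this change therefore did not carry over from one core to the other in this series, although only two pairs of compounds bear on the point and they set no general rule: the same change on two cores in this assay, a 1.7-fold lower number (0.22 log units; within the scatter) from compound 1 to compound 2 and an at least 11-fold lower number (1.05 log units; beyond the scatter) from compound 3 to compound 4, at least 6.7-fold (0.82 log units) apart, beyond the scatter of two such steps What the result does not show is the true size of the step on the core of compound 3, or why the two cores differ, since the entry for compound 3 is a limit of the assay and not a number: the limit of > 50000 nM in this assay, at which 1 of the 4 values shown sits.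

The compounds shown leave open whether another group at the same place on the six-membered ring, such as chloro, methoxy or an amine, would also separate the two cores. They also leave open how either core would respond if a carboxylic acid stood in place of the primary amide.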